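Amide ring size change in a dehydrogenase inhibitor series

A few compounds are considered here, and "the series" means these few. Any claim that something is new, unique, unknown or untested is made for them only; others in the source may bear on it.

Of the compounds shown here, three have been measured in an assay on isolated protein for inhibition of 15-hydroxyprostaglandin dehydrogenase [NAD(+)] (Homo sapiens), read by fluorescence, with a stated time of 15 min; a higher number here means a weaker inhibitor, a lower number a stronger inhibitor. Compound 1, `Cc1cc(-c2nnc3n2CCCCC3)c(C)n1-c1ccc(F)cc1`, gives 121 nM. Compound 2, `Cc1cc(-c2nnc3n2CCCCCC3)c(C)n1-c1ccccc1`, gives 242 nM. Compound 3, `Cc1cccc(-n2cnc3cc(C(=O)N4CC(C)CC(C)C4)ccc32)c1`, gives 271 nM. Among these three, compound 3 carries the highest number; its value and that of compound 2 lie within the usual scatter of each other, so the two cannot be ordered, whereas compound 1 sits at a clearly lower number than compound 3, a difference beyond the scatter.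

Compound 4, `Cc1cccc(-n2cnc3cc(C(=O)N4CCCC4)ccc32)c1`, has not yet been measured. It differs from compound 3 in one place: pyrrolidin-1-yl in place of 3,5-dimethylpiperidin-1-yl on a carbonyl carbon. For the measured compounds named here, no measured pair in this set shows what such a change does, so the expectation rests on the change itself and on the value of compound 3 in this assay . A smaller saturated ring on the amide, with the two methyl groups gone, is expected to shift the number somewhat, most likely toward a higher value, though a shift no larger than the scatter is also plausible.

Compound 4 is therefore estimated at 400 nM in this assay , with a range from 150 nM to 1100 nM. The step this estimate implies is a 1.5-fold higher number from compound 3 to compound 4 (0.17 log units; within the scatter), expected to be modest and uncertain in size.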

Compound 4, half-maximal inhibitory concentration: 383 nM
The estimate for compound 4 lay 1.0-fold (0.02 log units) above the measured number, and the stated range covers the measured number.
By their numbers in this assay, from the lowest: compounds 1, 2, 3 and 4 (each within the scatter of the next, the first and the last beyond it).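

Exchanging 3,5-dimethylpiperidin-1-yl for pyrrolidin-1-yl on a carbonyl carbon gives, in this assay, a 1.4-fold higher number from compound 3 to compound 4 (0.15 log units; within the scatter), so the two compounds cannot be ordered. For the compounds shown here, this is the first pair in the set that differs in one place, and it shows that at this position a five-membered non-aromatic ring of 5 heavy atoms can stand in for a six-membered one of 8 heavy atoms, without its two methyl groups, and leave the number within the scatter. Nothing measured here speaks to what lies behind this result.

The step changes ring size and removes the two methyl groups at once, so the compounds shown cannot separate the two changes, and an unsubstituted piperidin-1-yl on the same carbonyl carbon would be needed to tell them apart. They also leave open whether this position would accept a ring with a second hetero atom, such as morpholin-4-yl, or an open-chain diethylamino group in place of a ring.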